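Triazole nitrogen substituent: carboxymethyl to hydroxypropyl

The source may report more compounds than this note shows. Statements on the series, on what has been measured and on what is new or still open speak of the compounds shown alone.

Working notes on the series built on the core of compound 1 `C#CCNCCN(C)CCNc1ccnc2cc(Cl)ccc12`. In a functional assay on HCC827 cells (Homo sapiens) for antiproliferative activity, read by sulforhodamine B assay, with a stated time of 72 h (a lower number here means a stronger inhibitor, a higher number a weaker inhibitor), compound 1 gives 105000 nM. Compound 2 `CN(CCNCc1cn(-c2cccc(Cl)c2)nn1)CCNc1ccnc2cc(Cl)ccc12`, which carries 3-chlorophenyl on the aromatic nitrogen, gives 9400 nM in this assay. For compound 3 `CN(CCNCc1cn(CC(=O)O)nn1)CCNc1ccnc2cc(Cl)ccc12` the reading > 200000 nM is a limit of the assay and not a number, namely (the limit of > 200000 nM in this assay, at which 1 of the 3 values shown sits). Compound 3 therefore stands at the weak end of what has been measured: the step of an at least 21-fold higher number from compound 2 to compound 3 (1.32 log units; beyond the scatter) reaches that limit from the 3-chlorophenyl bearer, while the step of an at least 1.9-fold higher number from compound 1 to compound 3 (0.27 log units; that floor lies within the scatter) is small and sits within the scatter.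

Compound 4 `CN(CCNCc1cn(CCCO)nn1)CCNc1ccnc2cc(Cl)ccc12` differs from compound 3 by 2-hydroxyethyl in place of carboxy on a saturated chain carbon bound to an aromatic nitrogen. Neither measured step matches this change exactly. The step of an at least 21-fold higher number from compound 2 to compound 3 (1.32 log units; beyond the scatter) concerns the aromatic nitrogen, the same place, but exchanges a different group; the step of an at least 1.9-fold higher number from compound 1 to compound 3 (0.27 log units; that floor lies within the scatter) shows that the ethynyl end of compound 1 already sits close to the limit reached by compound 3. Compound 4 keeps a chain, 3-hydroxypropyl, on the aromatic nitrogen rather than a ring. The step of an at least 2.5-fold lower number from compound 3 to compound 4 (0.39 log units; beyond the scatter) is expected to run downward, towards the value of compound 1 at 105000 nM. A reading for compound 4 of the same kind as that of compound 3 cannot be excluded. Compound 4 is estimated at 80000 nM, with a range from 25000 nM to 200000 nM.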

Compound 4, half-maximal inhibitory concentration: > 200000 nM
Compound 4: no number, only a limit (the forecaster's own chance of this, stated with the estimate: 35%); at least 2.5-fold (0.39 log units) between middle value and limit.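

In this assay, compound 4 gives a limit and not a number, as compound 3 does: the limit of > 200000 nM in this assay, at which 2 of the 4 values shown sit.

Exchanging carboxy for 2-hydroxyethyl on a saturated chain carbon bound to an aromatic nitrogen therefore does not bring the reading back within the range of the assay, and the step between these two limits cannot be read. Of the three groups shown on the aromatic nitrogen, only 3-chlorophenyl gives a number, and putting 3-hydroxypropyl in its place gives an at least 21-fold higher number from compound 2 to compound 4 (1.32 log units; beyond the scatter), while the exchange of ethynyl for 1-(3-hydroxypropyl)-1H-1,2,3-triazol-4-yl gives an at least 1.9-fold higher number from compound 1 to compound 4 (0.27 log units; that floor lies within the scatter), so that only a floor is known for that step.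

The compounds shown leave open whether a plain phenyl, a benzyl or a longer alkyl chain on the aromatic nitrogen would give a reading close to that of compound 2 at 9400 nM. They also leave open whether a chain ending in an amine would give a number at all, and how far compound 3 and compound 4 lie past their limits.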